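Trifluoromethyl to Methyl on a Fused Core

The compounds below may be only part of what the source reports. "The series", "measured", "known", "first", "only" and "open" are said of these compounds alone.

Compound 1 `Nc1nc2cc(C(F)(F)F)ccn2c1-c1ccc(O)cc1` and compound 2 `Nc1nc2c(C(F)(F)F)cccn2c1-c1ccc(O)cc1` are built from the same atoms joined differently; the difference between the two cores is not broken down here. In an assay on isolated protein for inhibition of ubiquitin carboxyl-terminal hydrolase 47 (Homo sapiens) (on this read-out lower numbers stand for stronger inhibition and higher numbers for weaker inhibition), compound 1 gives only the limit > 100000 nM. In this assay compound 2 also gives only the limit > 100000 nM. Compound 3 `Cc1ccn2c(-c3ccc(O)cc3)c(N)nc2c1` carries methyl in place of trifluoromethyl on an aromatic carbon. In this assay compound 3 again gives only the limit > 100000 nM. The step that the two limits leave unreadable from compound 1 to compound 3 therefore cannot be read. Compound 4 `Cc1cccn2c(-c3ccc(O)cc3)c(N)nc12`, not yet measured, carries the same kind of change, (methyl in place of trifluoromethyl on an aromatic carbon), but at a place that is ortho to a fused ring and two atoms from the ring nitrogen rather than opposite the ring nitrogen and para to a fused ring. Because (the limit of > 100000 nM in this assay, at which 3 of the 3 values shown sit), compound 4 is expected to stay near that limit, with the step that the limit leaves unreadable from compound 2 to compound 4 expected to be small. The estimate for compound 4 is 150000 nM.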

Compound 4, half-maximal inhibitory concentration: > 100000 nM
Compound 4 gave a limit, no number; the forecaster's own chance of this, stated with the estimate: 85%; the middle value does not contradict the limit.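

Compound 4 gives > 100000 nM in this assay as a limit, not a number. Among these compounds, compound 2 also gives only a limit, so no step between compound 2 and compound 4 can be read. The compounds shown leave open which change to the shared core, if any, would give a readable value in this assay at all.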